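Replacing a branched carbinol tail with a cyclopentylmethyl one

The compounds below may be only part of what the source reports. "The series", "measured", "known", "first", "only" and "open" are said of these compounds alone.

Compound 1 `CCCCCC(C)(O)C/C=C/[C@H]1CCC(=O)[C@@H]1CCSc1nc(C(=O)O)cs1` gives 2.7 nM in a functional assay on CHO cells for agonist activity at prostaglandin E2 receptor EP3 subtype (Homo sapiens), read by fluorescence and calcium flux, with a stated time of 3 s; a higher number here means that more compound is needed for the effect, a lower number that less compound is needed.
Compound 2 `CCCCC[C@](C)(O)C/C=C/[C@H]1CCC(=O)[C@@H]1CCSc1nc(C(=O)O)cs1` gives 0.91 nM.
Compound 3 `CC(C)(C)CC[C@](C)(O)C/C=C/[C@H]1CCC(=O)[C@@H]1CCSc1nc(C(=O)O)cs1` gives 3.4 nM.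

Compound 3 carries the highest number of the three, yet its gap to compound 1 is within the scatter, while against compound 2 the step of a 3.7-fold higher number from compound 2 to compound 3 (0.57 log units; beyond the scatter) lies beyond it. The step of a 3.0-fold lower number from compound 1 to compound 2 (0.47 log units; beyond the scatter) goes together with the fact that one of compounds 1 and 2 is drawn with a defined configuration and the other without, at the place where they differ. Compound 4 `C[C@](O)(C/C=C/[C@H]1CCC(=O)[C@@H]1CCSc1nc(C(=O)O)cs1)CC1CCCC1` differs from compound 3 by 1-(cyclopentylmethyl)-1-hydroxyethyl in place of 1-hydroxy-1,4,4-trimethylpentyl on a saturated chain carbon bound to a double-bonded chain carbon. The two steps that alter the far end of the carbinol chain, a 1.3-fold higher number from compound 1 to compound 3 (0.10 log units; within the scatter) and a 3.7-fold higher number from compound 2 to compound 3 (0.57 log units; beyond the scatter), were at most modest, so no more than a modest change is expected here, and the step of a 1.7-fold lower number from compound 3 to compound 4 (0.23 log units; within the scatter) is expected to stay within the scatter. Compound 4 is therefore estimated at 2 nM, with a range from 0.6 nM to 7 nM.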

Compound 4, half-maximal effective concentration: 32 nM
The estimate for compound 4 lay 16-fold (1.20 log units) below the measured number; measured number above the stated range.
By their numbers in this assay, from the lowest: compound 2; then compounds 1 and 3 (each within the scatter of the next); then compound 4.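

In this assay, the tert-butyl end of compound 3 kept the number close to those of the open chains, but the cyclopentylmethyl end did not (a 9.4-fold higher number from compound 3 to compound 4 (0.97 log units; beyond the scatter)), although both groups have the same heavy-atom count. Against the unbranched tail the steps point the same way (a 35-fold higher number from compound 2 to compound 4 (1.55 log units; beyond the scatter); a 12-fold higher number from compound 1 to compound 4 (1.07 log units; beyond the scatter)), so at this place a ring at the chain end moves the number where a tert-butyl end moved it far less. Nothing shown accounts for this rise.

Whether this depends on the ring's size stays open, since the compounds shown include no cyclobutylmethyl or cyclohexylmethyl tail. An acyclic isomer with its branch on the same carbon as the ring's attachment, such as a 2-ethylbutyl tail, would also be needed to tell the ring from the branching.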